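The source may hold more compounds than are shown below. What is called first, only, known or untested is meant among the compounds shown, and "the series" means these compounds.

Compound 1 `CCOC(=O)c1c(-c2ccc(Cl)cc2)cc(-c2ccccc2)nc1N1CCCCC1` has been tested in a functional assay on the whole organism (strain Wister albino) for inhibition, with Rattus norvegicus as the target, read by paw edema, with stated times of 1 h and 4 h, at a dose of 50 mg/kg by the intraperitoneal route (a higher number here means more inhibition at the dose given (going by the name of the read-out), a lower number less inhibition), where compound 1 gives 103%. Of the two numbers recorded so far, compound 1 stands highest; its nearest neighbour is compound 2 `CCOC(=O)c1c(-c2ccc(Cl)c(Cl)c2)cc(-c2ccccc2)nc1N1CCCCC1`, which in this assay gives 95.1%. Within the data shown here, the only measured step, a number 7.9 percentage points lower from compound 1 to compound 2 (within the scatter), comes from a chloro in place of hydrogen on an aromatic carbon and lies within the scatter, so the two values cannot be put in order. Compound 3 `CCOC(=O)c1c(-c2ccc(Cl)cc2)cc(-c2ccccc2)nc1N1CCN(C)CC1` is the next compound awaiting measurement. It differs from compound 1 in one place: 4-methylpiperazin-1-yl in place of piperidin-1-yl on an aromatic carbon. Among the measured compounds shown here, no measured step bears on this exchange of piperidin-1-yl for 4-methylpiperazin-1-yl; the single step recorded, a number 7.9 percentage points lower from compound 1 to compound 2 (within the scatter), concerns another change and offers no direction here. With nothing to draw on for this change, no step beyond the scatter is expected, though the range is left wide. In this assay compound 3 is therefore expected to give 90%, with a range from 65% to 105%. The expected step of a number 13 percentage points lower from compound 1 to compound 3 (beyond the scatter) is accordingly estimated to be modest.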

Compound 3, a percentage reported as inhibition, in the whole organism at one dose (the size of the read-out at that dose, not a potency): 55.6%
Compound 3: middle estimate off by 34.4 percentage points, on the high side; the whole stated range lies above it.
By their numbers in this assay, from the lowest: compound 3; then compounds 2 and 1 (each within the scatter of the next).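

In this assay, among these compounds, the place next to the ring nitrogen and ortho to the ethoxycarbonyl group proves sensitive to the group it carries: 4-methylpiperazin-1-yl in place of piperidin-1-yl gives a number 47.4 percentage points lower from compound 1 to compound 3 (beyond the scatter), whereas the only earlier step, a number 7.9 percentage points lower from compound 1 to compound 2 (within the scatter), came from a change elsewhere on the molecule. The exchange keeps a six-membered non-aromatic ring at this place, with no hydrogen-bond donors and no net charge, and alters it only to 2 hetero atoms rather than 1 and 7 heavy atoms rather than 6, so even this limited change in the ring is enough for a large step. No measurement available here accounts for the size of that step.

The compounds shown leave open whether the lower number goes with the second ring nitrogen or with the methyl group on it, a question that a piperazin-1-yl, 4-methylpiperidin-1-yl or morpholin-4-yl group at this place could help to separate. They also leave open whether the same exchange would give a step of similar size on compound 2, which carries the second chloro group.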